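The source may report more compounds than this note shows. Statements on the series, on what has been measured and on what is new or still open speak of the compounds shown alone.

In a functional assay on A549 cells (Homo sapiens) for antiproliferative activity, read by MTT assay, with a stated time of 48 h (on this read-out higher numbers stand for weaker inhibition and lower numbers for stronger inhibition), compound 1 `Cc1ccccc1-n1nncc1CN1C(=O)C2(C(C#N)=C(N)Oc3c(N)cc4nc5ccccc5nc4c32)c2ccccc21` gives 31700 nM. Compound 2 `CC(=O)Nc1ccc(-n2nncc2CN2C(=O)C3(C(C#N)=C(N)Oc4c(N)cc5nc6ccccc6nc5c43)c3ccccc32)cc1` reaches only the limit of this assay at > 50000 nM. Compound 3 `CCOc1ccc(-n2nncc2CN2C(=O)C3(C(C#N)=C(N)Oc4c(N)cc5nc6ccccc6nc5c43)c3ccccc32)cc1` likewise reaches only the limit at > 50000 nM. Compound 3 thus stands at the limit of > 50000 nM in this assay, at which 2 of the 3 values shown sit, so only floors of its steps can be read: an at least 1.5-fold higher number from compound 1 to compound 3 (0.19 log units; that floor lies within the scatter), echoed by an at least 1.5-fold higher number from compound 1 to compound 2 (0.19 log units; that floor lies within the scatter). Compound 4 `CCOc1ccccc1-n1nncc1CN1C(=O)C2(C(C#N)=C(N)Oc3c(N)cc4nc5ccccc5nc4c32)c2ccccc21` differs from compound 3 by 2-ethoxyphenyl in place of 4-ethoxyphenyl on an aromatic nitrogen. For the measured compounds named here, no measured step moves a group on that ring in this way; compound 1, bearing 2-methylphenyl, gives a number, while compounds 2 and 3, bearing 4-acetamidophenyl and 4-ethoxyphenyl, give only limits. The expected step is an at least 1.2-fold lower number from compound 3 to compound 4 (0.09 log units; that floor lies within the scatter), its direction uncertain. Compound 4 is estimated at 40000 nM, within 15000 nM to 100000 nM.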

Compound 4, half-maximal inhibitory concentration: > 50000 nM
Compound 4: only a limit was reported; the forecaster's own chance of this, stated with the estimate: 45%; at least 1.2-fold (0.09 log units) between middle value and limit.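

In this assay compound 4 gives > 50000 nM, a limit and not a number, so moving the ethoxy group from 4-ethoxyphenyl to 2-ethoxyphenyl yields no measurable change. The steps to compound 4 from compound 2 and compound 3 cannot be read, and the comparison with the methyl group gives only a floor: an at least 1.5-fold higher number from compound 1 to compound 4 (0.19 log units; that floor lies within the scatter). Most of the series now shares one reading: the limit of > 50000 nM in this assay, at which 3 of the 4 values shown sit.

As far as these compounds go, it remains open whether an amine or a carboxylic acid in place of ethoxy on this phenyl ring would give a readable number. From the compounds shown here alone, whether the group's position on that ring matters at all also remains open.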